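The compounds below may be only part of what the source reports. "The series", "measured", "known", "first", "only" and "open" are said of these compounds alone.

Measured in a functional assay on the whole organism for inhibition, with Cavia porcellus as the target; a higher number here means that more compound is needed for the effect, a lower number that less compound is needed
Compound 1 (`CCCn1c(=O)n(CCN(C)C)c(=O)c2[nH]cnc21`) gives 5.65 mg/kg
Compound 2 (`CCCn1c(=O)n(C)c(=O)c2[nH]cnc21`) gives 4.44 mg/kg

Going by the values given here, compound 2 stands level with compound 1, its only measured neighbour, within the scatter. Compound 3 (`CCCn1cnc2c1c(=O)n(C)c(=O)n2CCC`) has not yet been measured. It differs from compound 2 by propyl in place of hydrogen on an aromatic nitrogen and so carries propyl in place of hydrogen on an aromatic nitrogen. Among the compounds with values here, the only guide is a 1.3-fold lower number from compound 1 to compound 2 (0.10 log units; within the scatter) but that change lay on a saturated chain carbon, not on this aromatic nitrogen, so it bears only loosely on the new change. Within the data shown here, no step at this place has been measured. In this assay a modest move towards a higher number is expected, though not one clearly beyond the scatter. The expected step is a 1.8-fold higher number from compound 2 to compound 3 (0.26 log units; within the scatter) and it remains uncertain. For compound 3 the estimated value is 8 mg/kg with an expected range of 2.5 mg/kg to 25 mg/kg around it.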

Compound 3, dose for half-maximal effect: 27.5 mg/kg
Compound 3: middle estimate off by 3.4-fold (0.54 log units), on the low side; the whole stated range lies below it.
By their numbers in this assay, from the lowest: compounds 2 and 1 (each within the scatter of the next); then compound 3.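

Putting propyl in place of hydrogen on the aromatic nitrogen of the five-membered ring gives a 6.2-fold higher number from compound 2 to compound 3 (0.79 log units; beyond the scatter) in this assay. This is the only step among these compounds that lies beyond the scatter, so more compound is needed once this nitrogen carries propyl. The earlier change on the saturated chain carbon gave no such separation, which shows that the number in this series can respond to a change at this aromatic nitrogen even though it stayed level at that chain carbon.

Going by these compounds, a single step cannot separate the loss of the hydrogen from the arrival of propyl, and it remains open whether ethyl, butyl or a chain ending in a carboxylic acid on this nitrogen would read closer to compound 2 or to compound 3. Nothing measured on these compounds accounts for the rise at this nitrogen.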